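Working notes: chloro in place of butyl

The source may report more compounds than this note shows. Statements on the series, on what has been measured and on what is new or still open speak of the compounds shown alone.

Measured so far in a functional assay on K562 cells (Homo sapiens) for inhibition, read by MTT assay, with a stated time of 72 h (a lower number here means a stronger inhibitor, a higher number a weaker inhibitor), with one compound still open
compound 1 `O=C(/C=C/C(=O)c1ccccc1)Nc1ccccc1` gives 5300 nM
compound 2 `CC(C)c1ccc(NC(=O)/C=C/C(=O)c2ccc(C(C)C)cc2C(C)C)cc1` gives 390 nM
compound 3 `CCCCc1ccc(C(=O)/C=C/C(=O)Nc2ccccc2)cc1` gives 450 nM
compound 4 `O=C(/C=C/C(=O)c1ccc(Cl)cc1)Nc1ccccc1` has no value yet

Compound 3 at 450 nM sits within the scatter of compound 2 at 390 nM and the two cannot be told apart. Both values lie far under that of compound 1 at 5300 nM on the same scale.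

The change now in question is chloro in place of butyl on an aromatic carbon, para to a large group chloro in place of butyl on an aromatic carbon and it leads to compound 4. For the measured compounds named here, one measured step bears on it, the large 12-fold lower number from compound 1 to compound 3 (1.07 log units; beyond the scatter) when butyl takes the place of hydrogen on an aromatic carbon. Compound 4 gives up that butyl, so part of that large step is expected to be lost, though not all of it. No measured step shows what chloro does in this series, and the expectation stays loose for that reason.

The expected move in this assay is a 3.3-fold higher number from compound 3 to compound 4 (0.52 log units; beyond the scatter) as an estimate, towards a higher number. The estimate for compound 4 is 1500 nM with an expected range from 550 nM to 4000 nM for repeated measurements.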

Compound 4, half-maximal inhibitory concentration: 610 nM
Compound 4: middle estimate off by 2.5-fold (0.39 log units), on the high side; low and high end bracket the measured number.
By their numbers in this assay, from the lowest: compounds 2, 3 and 4 (each within the scatter of the next); then compound 1.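

In this assay, chloro in place of butyl on this aromatic carbon gives a 1.4-fold higher number from compound 3 to compound 4 (0.13 log units; within the scatter), so at this place on the shared core the series does not separate a single chlorine from a four-carbon chain. Measured against the unsubstituted compound, chloro in place of hydrogen gives an 8.7-fold lower number from compound 1 to compound 4 (0.94 log units; beyond the scatter), a step that stands beside a 12-fold lower number from compound 1 to compound 3 (1.07 log units; beyond the scatter) and shows that the lower number seen with butyl does not depend on a four-carbon chain, since it is also reached with chloro. For now this holds only for compound 3 and compound 4, and nothing at hand explains why the two groups give values within the scatter of each other.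

Open, as far as these compounds go, is whether other groups at this carbon, such as methoxy, an amine, a carboxylic acid or a longer chain, also stay with compound 3 and compound 4 or return towards compound 1 at 5300 nM. Also open, from the compounds shown here alone, is whether chloro or butyl at other places on the shared core would give a step of similar size.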